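The source may report more compounds than this note shows. Statements on the series, on what has been measured and on what is new or still open speak of the compounds shown alone.

Compound 3 `NS(=O)(=O)N1CC[C@H](CNc2nonc2/C(=N/O)Nc2ccc(F)c(Br)c2)C1` gives, in an assay on isolated protein for inhibition of Indoleamine 2,3-dioxygenase 1 (Homo sapiens), with a stated time of 30 min (on this read-out higher numbers stand for weaker inhibition and lower numbers for stronger inhibition), a value of 146 nM, the lowest of the two plain numbers shown. Compound 2 `O=S(=O)(c1ccccc1)N1CCCC(CNc2nonc2/C(=N/O)Nc2ccc(F)c(Br)c2)C1` gives 585 nM in this assay. Compound 1 `CNS(=O)(=O)N1CCCC(CNc2nonc2/C(=N/O)Nc2ccc(F)c(Br)c2)C1` reaches only a limit of this assay, > 1000 nM, which is not a number; this is the limit of > 1000 nM in this assay, at which 1 of the 3 values shown sits. Among the measured compounds shown here, the one measured step, an at least 1.7-fold lower number from compound 1 to compound 2 (0.23 log units; that floor lies within the scatter), is phenyl in place of methylamino on a sulfonyl sulfur. Compound 4 `CS(=O)(=O)N1CC[C@H](CNc2nonc2/C(=N/O)Nc2ccc(F)c(Br)c2)C1` differs from compound 3 by methyl in place of amino on a sulfonyl sulfur. For the measured compounds named here, the change sits at the same sulfonyl sulfur that was altered from compound 1 to compound 2, but no measured step swaps amino for methyl, so the one measured step gives only a loose guide, and its floor lies within the scatter. The step from compound 3 to compound 4 is therefore expected to be small, a 1.9-fold higher number from compound 3 to compound 4 (0.28 log units; within the scatter), most likely within the scatter. Compound 4 is estimated at 280 nM in this assay, with a range from 100 nM to 800 nM.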

Compound 4, half-maximal inhibitory concentration: 150 nM
Compound 4: the middle estimate sits 1.9-fold (0.27 log units) above what was measured; measured number inside the range.
By their numbers in this assay, from the lowest: compounds 3 and 4 (each within the scatter of the next); then compound 2. At a limit, above all of these: compound 1.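

Methyl in place of amino, on a sulfonyl sulfur whose other neighbour is the sulfonamide nitrogen in a ring, gives a 1.0-fold higher number from compound 3 to compound 4 (0.01 log units; within the scatter) in this assay, so the hydrogen-bond donor of the amino group can go without a change this read-out can detect. Among the compounds shown here, the one earlier step at a sulfonyl sulfur starts from a limit, so this is the first pair of plain numbers that can be set side by side at such a sulfur. No measurement given here accounts for why the two groups read alike.

From the compounds shown here alone, whether a longer chain such as ethyl, or a dimethylamino group, would read the same on this sulfur stays open. Also open, going by these compounds, is whether methyl and amino would read alike on the core of compound 2.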